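A few compounds are considered here, and "the series" means these few. Any claim that something is new, unique, unknown or untested is made for them only; others in the source may bear on it.

Measured so far in an ADME assay on HEK293 cells (Homo sapiens) for cytotoxicity, read by MTT assay, with a stated time of 48 h; on this read-out higher numbers stand for weaker inhibition and lower numbers for stronger inhibition:
- compound 1 `C=C1CCC[C@]2(C)CCC(C=O)=CC[C@@]12C`: 734000 nM
- compound 2 `CC1(C)CCCC2=CC=C(C=O)CC[C@]21C`: 696000 nM
- compound 3 `C=C1CCC[C@]2(C)CCC(c3cn(-c4ccc(OC)cc4)nn3)=CC[C@@]12C`: 410000 nM

Compound 3, at 410000 nM, stands within the usual scatter of both compound 1 and compound 2, so the three values cannot be ranked. Going by the values given here, no pair of measured compounds differs in one place only, which leaves no direct measure of what a change on the aromatic nitrogen does.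

Compound 4 `C=C1CCC[C@]2(C)CCC(c3cn(-c4ccccc4C(C)=O)nn3)=CC[C@@]12C` keeps the core of compound 3 but carries 2-acetylphenyl in place of 4-methoxyphenyl on an aromatic nitrogen. Compound 1 at 734000 nM lacks that five-membered aromatic ring altogether, yet it lies within the scatter of compound 3 at 410000 nM. On that evidence alone, no step beyond the scatter is expected in this assay, and no direction can be favoured with confidence. The expected change is small: a 1.1-fold lower number from compound 3 to compound 4 (0.03 log units; within the scatter). For compound 4 the estimated value is 380000 nM, with an expected range of 170000 nM to 750000 nM.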

Compound 4, half-maximal inhibitory concentration: 524000 nM
The estimate for compound 4 lay 1.4-fold (0.14 log units) below the measured number; low and high end bracket the measured number.
By their numbers in this assay, from the lowest: compounds 3, 4, 2 and 1 (each within the scatter of the next).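

In this assay, going by these compounds alone, the change from 4-methoxyphenyl to 2-acetylphenyl on the aromatic nitrogen gives the first step that can be read between two compounds differing in one place: a 1.3-fold higher number from compound 3 to compound 4 (0.11 log units; within the scatter), which lies within the scatter. At this position, then, this exchange of one substituted phenyl group for another, with the shared core unchanged, leaves no measurable trace on this read-out, although a single pair says nothing about other groups there. No measurement shown here speaks to what lies behind this result.

As far as these compounds go, whether an amine or a carboxylic acid on that phenyl ring, or a longer alkyl chain in its place on the nitrogen, would give a step beyond the scatter remains open. Steps involving compound 1 or compound 2 cannot be read, so what the five-membered aromatic ring itself contributes also stays unresolved.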